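Removing a Ring Methyl: An Expectation for Compound 4

The source may report more compounds than this note shows. Statements on the series, on what has been measured and on what is new or still open speak of the compounds shown alone.

Measured so far in an assay on isolated protein for inhibition of ribosomal protein S6 kinase alpha-1 (Homo sapiens), read by mobility shift assay, tested at 30 uM; a lower number here means less inhibition, a higher number more inhibition at the concentration tested (going by the name of the read-out):
- compound 1, `Cc1cc2[nH]nc(N)c2c(N2CCCCC2)n1`, gives 46%
- compound 2, `Cc1cc2c(c(N)nn2C)c(N2CCCCC2)n1`, gives 23%
- compound 3, `Cc1cc2c(cn1)c(N)nn2C`, gives 1%

Compound 4, `Cc1cc2[nH]nc(N)c2cn1`, is not yet measured. It differs from compound 3 by hydrogen in place of methyl on an aromatic nitrogen. The same change links compound 2 to compound 1, (hydrogen in place of methyl on an aromatic nitrogen), where it gave a number 23 percentage points higher from compound 2 to compound 1 (beyond the scatter). The two cores differ by hydrogen in place of piperidin-1-yl on an aromatic carbon, a change that gave a number 22 percentage points lower from compound 2 to compound 3 (beyond the scatter), so compound 3 starts from the lowest number of the three. Within the data shown here, the step for compound 4 is expected to run in the same direction, a number 14 percentage points higher from compound 3 to compound 4 (beyond the scatter), but somewhat smaller, because the only measured instance, a number 23 percentage points higher from compound 2 to compound 1 (beyond the scatter), was made on a core carrying the piperidin-1-yl group that compound 3 lacks. Compound 4 is therefore estimated at 15%, within 0% to 35%.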

Compound 4, a percentage reported as inhibition, at one concentration (the size of the read-out at that concentration, not a potency): 11%
Estimate against measurement, compound 4: 4 percentage points above; measured number inside the range.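

In this assay, putting hydrogen in place of methyl on the aromatic nitrogen of the core without piperidin-1-yl gave a number 10 percentage points higher from compound 3 to compound 4 (within the scatter). Set beside the earlier step on the core carrying piperidin-1-yl, the new one cannot be told apart from it: the same change on two cores in this assay, a number 23 percentage points higher (beyond the scatter) from compound 2 to compound 1 and a number 10 percentage points higher (within the scatter) from compound 3 to compound 4, 13 percentage points apart, within the scatter of two such steps. This gives no sign that the core alters the effect of the change, but two pairs do not show that the step is equal on both cores, and the new step alone is not clear of the scatter.

The compounds shown leave open what a longer chain on the aromatic nitrogen, such as ethyl, would give. They also leave open whether morpholine in place of piperidin-1-yl, or an amide in place of the amino group, would keep the pattern.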